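Replacing the Acetyl of Compound 1

This account rests on a few compounds, and the source may have more. Where it says the series, first, only, none or still open, it means among the compounds named here.

Measured in an ADME assay on MDBK cells (Bos taurus) for cytotoxicity, read by MTT assay, with a stated time of 96 h; a lower number here means that less compound is tolerated, a higher number that more compound is tolerated:
- compound 1 `COc1ccc(-c2nc3cc(C(C)=O)ccc3[nH]2)c(OC)c1`: 73000 nM
- compound 2 `COc1ccc(-c2nc3cc(C(C)=O)ccc3[nH]2)c(OC)c1OC`: > 100000 nM (a limit)
- compound 3 `C/C(=N\NC(N)=O)c1ccc2[nH]c(-c3ccccc3)nc2c1`: > 100000 nM (a limit)

Among the measured compounds shown here, compound 1 is the only compound here with a measured number, 73000 nM. The other two results sit at the limit of > 100000 nM in this assay, at which 2 of the 3 values shown sit, so compound 1 cannot be placed precisely against them.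

Compound 4 `COc1ccc(-c2nc3cc(/C(C)=N/NC(N)=S)ccc3[nH]2)c(OC)c1` keeps the core of compound 1 but loses its acetyl, on an aromatic carbon, to a larger group with no common name: a group of 7 heavy atoms (3 carbon, 3 nitrogen, 1 sulfur; no ring) in place of a group of 3 heavy atoms (2 carbon, 1 oxygen; no ring), on an aromatic carbon.

For the measured compounds named here, no measured step covers this exact change. The only one, an at least 1.3-fold higher number from compound 1 to compound 2 (0.13 log units; that floor lies within the scatter), swaps a methoxy for hydrogen and leaves the acetyl untouched, so it bears on the question only weakly. Going by the values given here, compound 3 is the only measured compound without the acetyl. Compound 3 gives > 100000 nM, which is a limit of this assay. It offers some indirect support for good tolerance, but it differs from compound 4 elsewhere too, and its side chain contains no sulfur.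

No change beyond the scatter is therefore expected, though the uncertainty is wide. The expected change is a 1.5-fold lower number from compound 1 to compound 4 (0.16 log units; within the scatter). For compound 4 the estimated value is 50000 nM, with an expected range from 12000 nM to 100000 nM.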

Compound 4, half-maximal cytotoxic concentration: > 100000 nM
Compound 4 ended at the assay's limit; the forecaster's own chance of this, stated with the estimate: 30%; at least 2.0-fold (0.30 log units) between middle value and limit.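

In this assay, the new group on this aromatic carbon leaves tolerance intact: with a group of 7 heavy atoms, including sulfur, in place of the acetyl, compound 4 gives > 100000 nM, which is a limit of the assay. Among the compounds shown here, the change gives an at least 1.3-fold higher number from compound 1 to compound 4 (0.13 log units; that floor lies within the scatter), so no real rise can be claimed, but this is the first direct reading at this position, and it shows no fall in the number when the acetyl leaves the core of compound 1. With this result, most of the values shown now stand at the same limit, so they cannot be ranked against one another: the limit of > 100000 nM in this assay, at which 3 of the 4 values shown sit.

Going by these compounds, how much of compound 4 is actually tolerated therefore remains unknown, and the size of the change from the acetyl cannot be stated. The compounds shown also leave open whether this aromatic carbon would tolerate other replacements for the acetyl on the same core, such as an amine or a carboxylic acid.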